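A few compounds are considered here, and "the series" means these few. Any claim that something is new, unique, unknown or untested is made for them only; others in the source may bear on it.

Measured compounds:
- compound 1 `COc1ccc(S(=O)(=O)Nc2ccc(-c3nc4ccccc4o3)cc2)cc1`: > 100000 nM
- compound 2 `O=[N+]([O-])c1cc(S(=O)(=O)Nc2ccc3oc(-c4ccccc4)nc3c2)ccc1Cl`: 17000 nM

The read-out is an assay on cells for inhibition of HSP60/HSP10 (Homo sapiens), with a stated time of 60 min; on this read-out higher numbers stand for weaker inhibition and lower numbers for stronger inhibition. For compound 1 the value > 100000 nM is a limit of the assay and not a number; compound 1 sits at the limit (the limit of > 100000 nM in this assay, at which 1 of the 2 values shown sits), so only a bound is known for it. Among the compounds with values here, compound 2 gives 17000 nM in this assay and carries a different sulfonamide and a different arrangement of the core, so no single-change step between compound 1 and compound 2 exists and only the two values themselves can be set side by side.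

The unmeasured compound 3 `O=S(=O)(Nc1ccc(-c2nc3ccccc3o2)cc1)c1ccc(F)cc1` differs from compound 1 by fluoro in place of methoxy on an aromatic carbon, that is, 4-methoxyphenyl to 4-fluorophenyl. Within the data shown here, no measured step supports any direction for this change in this assay. Because compound 1 stands at the limit (the limit of > 100000 nM in this assay, at which 1 of the 2 values shown sits), the expected step from compound 1 to compound 3 is none beyond the scatter, a step that the limit leaves unreadable from compound 1 to compound 3, with a real chance that compound 3 again returns only a limit. Compound 3 is therefore expected at about 120000 nM, within 30000 nM to 400000 nM.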

Compound 3, half-maximal inhibitory concentration: 73000 nM
Compound 3: the middle estimate sits 1.6-fold (0.22 log units) above what was measured; measured number inside the range.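

For compound 1 the value > 100000 nM in this assay is a limit of the assay and not a number. With 4-fluorophenyl in place of 4-methoxyphenyl, on an aromatic carbon para to a large group, compound 3 gives 73000 nM, so this position now carries a readable number on the shared core. The change reads as an at least 1.3-fold lower number from compound 1 to compound 3 (0.13 log units; that floor lies within the scatter), and this is only a floor, so the true size of the step stays unknown because compound 1 is bounded: the limit of > 100000 nM in this assay, at which 1 of the 3 values shown sits.

Still open, going by these compounds, is whether an amine, a carboxylic acid or a longer alkoxy chain at this position would move the number in this assay, and whether a true value for compound 1 would set it apart from compound 3 by more than the scatter. Also open, on these data alone, is how far the fluoro change carries over to the different sulfonamide and core arrangement of compound 2, which gives 17000 nM.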